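Cyano in Place of Methoxy: An Unmeasured Step

The source may hold more compounds than are shown below. What is called first, only, known or untested is meant among the compounds shown, and "the series" means these compounds.

In an ADME assay on WI-38 cells (Homo sapiens) for cytotoxicity, read by MTT assay, with a stated time of 72 h (on this read-out lower numbers stand for stronger inhibition and higher numbers for weaker inhibition), compound 1 (`O=C(CCc1cccc2c1B(O)OC2)Nc1cccc(I)c1`) gives 71000 nM and compound 2 (`COc1ccc(-c2cccc(NC(=O)CCc3cccc4c3B(O)OC4)c2)cc1`) gives 1400 nM, the lower of the two numbers. Compound 3 (`N#Cc1ccc(-c2cccc(NC(=O)CCc3cccc4c3B(O)OC4)c2)cc1`) has not yet been measured. It departs from compound 2 in one place: cyano in place of methoxy on an aromatic carbon. The change lies para to a large group, so that 4-methoxyphenyl becomes 4-cyanophenyl. For the measured compounds named here, no measured step exchanges methoxy for another group, so the data give no direct size for this change. Going by the values given here, compound 3 keeps the ring gained in the large step of a 51-fold lower number from compound 1 to compound 2 (1.71 log units; beyond the scatter), which put 4-methoxyphenyl in place of iodo and is the only measured step with any bearing here, so nothing of that size is expected. In this assay the expected change is a 1.3-fold higher number from compound 2 to compound 3 (0.11 log units; within the scatter), none beyond the scatter, with a slightly higher number the likelier direction. Compound 3 is estimated at 1800 nM, with an expected range of 600 nM to 6000 nM.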

Compound 3, half-maximal inhibitory concentration: 12000 nM
For compound 3 the middle estimate is 6.7-fold (0.82 log units) below the measured one, and the stated range ends below it.
By their numbers in this assay, from the lowest: compound 2; then compound 3; then compound 1.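

In this assay, cyano in place of methoxy gives an 8.6-fold higher number from compound 2 to compound 3 (0.93 log units; beyond the scatter), so this position on the added ring is not indifferent, even though the two groups match in heavy-atom count and hydrogen-bond acceptor count. Adding the ring does not by itself fix the size of the gain over iodo: 4-cyanophenyl in place of iodo gives a 5.9-fold lower number from compound 1 to compound 3 (0.77 log units; beyond the scatter), a real drop but only part of the one seen with 4-methoxyphenyl, a 51-fold lower number from compound 1 to compound 2 (1.71 log units; beyond the scatter). Nothing measured alongside these numbers accounts for the difference between the two groups.

With only methoxy and cyano shown on this carbon, the compounds do not tell where a hydroxyl, an amine, a carboxylic acid, a fluorine atom or a longer chain such as ethoxy would fall relative to compound 2 and compound 3. For the compounds shown here, they also leave open whether methoxy would still give the lower number than cyano at another place on the ring, or on a core other than the one these three compounds share.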